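The source may report more compounds than this note shows. Statements on the series, on what has been measured and on what is new or still open speak of the compounds shown alone.

The measured compounds: compound 1 `COc1cccc(NC(=O)CSc2nc(Nc3ccccc3)c3ccccc3n2)c1` gives 21700 nM in a functional assay on MDA-MB-231 cells (Homo sapiens) for inhibition, read by MTT assay, with a stated time of 72 h; a higher number here means a weaker inhibitor, a lower number a stronger inhibitor. Compound 2 `C=CC(=O)Nc1cccc(NC(=O)CSc2nc(Nc3ccccc3)c3ccccc3n2)c1` gives 10200 nM. Compound 3 `C=CC(=O)Nc1cccc(NC(=O)CSc2nc(Nc3cccc(Br)c3)c3ccccc3n2)c1` gives 19400 nM.

Compound 3 holds the second highest of the three numbers; its gaps to compound 1 and to compound 2 both lie within the scatter, so no order among them can be read. Compound 4 `C=CC(=O)Nc1cccc(NC(=O)CSc2nc(Nc3ccc(CC)cc3)c3ccccc3n2)c1` differs from compound 3 by 4-ethylphenyl in place of 3-bromophenyl on a nitrogen on an aromatic ring. For the measured compounds named here, only one measured step touches that ring: a 1.9-fold higher number from compound 2 to compound 3 (0.28 log units; within the scatter), within the scatter. The other step, a 2.1-fold lower number from compound 1 to compound 2 (0.33 log units; beyond the scatter), sits at the far end of the molecule. Nothing measured swaps the bromine for an alkyl group, so the analyst expects no step beyond the scatter, a 1.2-fold lower number from compound 3 to compound 4 (0.08 log units; within the scatter). Compound 4 is therefore estimated at 16000 nM, with a range from 6000 nM to 45000 nM.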

Compound 4, half-maximal inhibitory concentration: 14400 nM
Compound 4: the middle estimate sits 1.1-fold (0.05 log units) above what was measured, and the stated range covers the measured number.
By their numbers in this assay, from the lowest: compounds 2, 4, 3 and 1 (each within the scatter of the next, the first and the last beyond it).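

In this assay the group on this nitrogen accepts a change of substituent without a readable shift: 4-ethylphenyl in place of 3-bromophenyl gives a 1.3-fold lower number from compound 3 to compound 4 (0.13 log units; within the scatter), and adding the ethyl group to the plain phenyl gives a 1.4-fold higher number from compound 2 to compound 4 (0.15 log units; within the scatter). Neither the bromo nor the ethyl compound thus separates from the plain phenyl of compound 2, so two different substituents now leave the number within the scatter. Nothing measured here offers a reason for this. As far as these compounds go, whether an amine, a carboxylic acid or a longer alkyl chain on this phenyl ring would produce a step beyond the scatter remains open.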